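Sulfur substituent swap: naphthalen-1-yl to phenethyl

This account rests on a few compounds, and the source may have more. Where it says the series, first, only, none or still open, it means among the compounds named here.

Measured so far in a functional assay on A-375 cells (Homo sapiens) for inhibition, read by CCK-8 assay, with a stated time of 72 h, tested at 8 uM; a higher number here means more inhibition of growth at the concentration tested, a lower number less inhibition of growth:
- compound 1 `Nc1ccccc1NC(=O)/C=C/c1ccc(CSc2ccc(C(F)(F)F)cn2)cc1` gives 3.96%
- compound 2 `Nc1ccccc1NC(=O)/C=C/c1ccc(CSc2cccc3ccccc23)cc1` gives 36%

Within the data shown here, compound 2 stands highest of the two numbers so far, well clear of compound 1, its only measured neighbour. The next structure is compound 3 `Nc1ccccc1NC(=O)/C=C/c1ccc(CSCCc2ccccc2)cc1`, which carries phenethyl in place of naphthalen-1-yl on a sulfur whose other neighbour is a saturated chain carbon. The counted difference is phenethyl in place of naphthalen-1-yl on a sulfur.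

Among the measured compounds shown here, one measured step bears on this change. It is a number 32 percentage points higher from compound 1 to compound 2 (beyond the scatter), a large step beyond the scatter, with naphthalen-1-yl in place of 5-(trifluoromethyl)pyridin-2-yl on the same sulfur. For the measured compounds named here, that step shows the group on this sulfur can move the number in this assay, but no measured compound carries phenethyl, so the evidence is thin. With compound 2 at the top of the measured range, a fall of moderate size is expected, smaller than the measured step, and a result within the scatter is not excluded.

The expected change is a number 16 percentage points lower from compound 2 to compound 3 (beyond the scatter).

For compound 3 the estimated value is 20%, with an expected range of 5% to 42%.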

Compound 3, percent growth inhibition at one concentration: 37.4%
Compound 3: the middle estimate sits 17.4 percentage points below what was measured, and the stated range covers the measured number.
By their numbers in this assay, from the lowest: compound 1; then compounds 2 and 3 (each within the scatter of the next).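

In this assay the change from naphthalen-1-yl to phenethyl on this sulfur gives a number 1.4 percentage points higher from compound 2 to compound 3 (within the scatter) even though the entering group has one six-membered aromatic ring of carbon only where the leaving group has 2, and its ring is reached through a saturated chain. Set against the 5-(trifluoromethyl)pyridin-2-yl group, phenethyl gives a number 33.4 percentage points higher from compound 1 to compound 3 (beyond the scatter) and so matches the large step already seen with naphthalen-1-yl, which means that step does not depend on a fused aromatic group sitting directly on the sulfur. No measurement shown accounts for these two groups falling within the scatter of each other or for compound 1 lying so far from both.

As far as these compounds go, it remains open whether the low number of compound 1 goes with its trifluoromethyl group or with its pyridine nitrogen, as a plain phenyl or pyridin-2-yl group on the sulfur would separate the two. Also open, from the compounds shown here alone, is how far the chain on the sulfur can vary, for example a benzyl group, a longer chain ending in phenyl, or a chain ending in an amine or a carboxylic acid.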